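From trichlorophenyl to methoxythiophene: an untested swap

The source may report more compounds than this note shows. Statements on the series, on what has been measured and on what is new or still open speak of the compounds shown alone.

Among the measured compounds shown here, compound 1 `O=C(/C(=C\c1cc(Cl)cc(Cl)c1Cl)S(=O)(=O)Cc1ccc(Cl)cc1)c1ccc(Br)cc1` gives 1000 nM in a functional assay on DU-145 cells (Homo sapiens) for inhibition, read by trypan blue exclusion, with a stated time of 96 h (on this read-out lower numbers stand for stronger inhibition of growth and higher numbers for weaker inhibition of growth), and so stands level with the only other compound measured so far. Compound 2 `COc1cc(C(=O)/C(=C\c2ccc(O)c([N+](=O)[O-])c2)SCc2ccc(Br)cc2)cc(OC)c1OC` gives 1000 nM in this assay as well. The two differ in more than one place, so they reveal nothing about the effect of any single change.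

Compound 3 `COc1ccsc1/C=C(\C(=O)c1ccc(Br)cc1)S(=O)(=O)Cc1ccc(Cl)cc1` has not yet been measured. The change 3-methoxythiophen-2-yl in place of 2,3,5-trichlorophenyl on a double-bonded chain carbon bound to a double-bonded chain carbon puts 3-methoxythiophen-2-yl in place of 2,3,5-trichlorophenyl on a double-bonded chain carbon bound to a double-bonded chain carbon. For the measured compounds named here, no measured pair shows what such a swap does, so neither direction is favoured, and compound 1 at 1000 nM remains the natural starting point. The expected step of no change at the digits printed from compound 1 to compound 3 (within the scatter) is none beyond the scatter. The estimated value for compound 3 is 1000 nM with an expected range from 300 nM to 3500 nM for now.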

Compound 3, concentration for 50% growth inhibition: 50000 nM
The estimate for compound 3 lay 50-fold (1.70 log units) below the measured number; the whole stated range lies below it.
By their numbers in this assay, from the lowest: compounds 1 and 2 (each within the scatter of the next); then compound 3.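

The position on this double-bonded chain carbon is clearly sensitive to what it carries: in this assay, 3-methoxythiophen-2-yl in place of 2,3,5-trichlorophenyl gives a 50-fold higher number from compound 1 to compound 3 (1.70 log units; beyond the scatter) and so a large loss of growth inhibition. Among the compounds shown here, compound 1 and compound 2 differ in more than one place, so this pair gives the first reading of a single change, and that change is not a neutral swap. Nothing available explains the size of this step.

The swap alters the ring and its substituents together, so the result cannot separate the loss of the three chlorine atoms from the arrival of the thiophene ring or the methoxy group. From the compounds shown here alone, it also remains open whether an unsubstituted phenyl, or a thiophen-2-yl without the methoxy, would read closer to compound 1 or to compound 3.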